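Selenium substituent trimming in a quinazoline-type series

The source may report more compounds than this note shows. Statements on the series, on what has been measured and on what is new or still open speak of the compounds shown alone.

Measured so far in a functional assay on HT-29 cells (Homo sapiens) for cytotoxicity, read by MTT assay, with a stated time of 72 h; a lower number here means a stronger inhibitor of growth, a higher number a weaker inhibitor of growth:
- compound 1 `CCCCC[Se]c1nc(N)c2ccccc2n1`: 40300 nM
- compound 2 `C[Se]c1nc(N)c2ccccc2n1`: 27600 nM
- compound 3 `C[Se]c1nc(N)c2cccnc2n1`: 44100 nM

The three numbers sit close together. The step of a 1.5-fold lower number from compound 1 to compound 2 (0.16 log units; within the scatter) is within the scatter, so nothing separates compound 1 from compound 2 in this assay. Compound 3 carries a different shared core and gives 44100 nM, which is likewise no more than the scatter away from compound 2. On the numbers shown, compound 2 cannot be set apart from either neighbour.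

Compound 4 `Nc1nc([SeH])nc2ccccc12` is not yet measured. It differs from compound 2 in one place: hydrogen in place of methyl on a selenium. Among the measured compounds shown here, the only measured step that bears on a shortened selenium substituent is a 1.5-fold lower number from compound 1 to compound 2 (0.16 log units; within the scatter), and that step stayed within the scatter when four chain carbons were removed. For the measured compounds named here, the remaining change, from methyl to hydrogen on the selenium, is smaller still in what is counted, and no measured pair shows a selenium bearing hydrogen. On that basis no step beyond the scatter is expected in this assay, in either direction.

Compound 4 is therefore estimated at 30000 nM, with a range from 10000 nM to 90000 nM, which means an expected step of a 1.1-fold higher number from compound 2 to compound 4 (0.04 log units; within the scatter).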

Compound 4, concentration for 50% growth inhibition: 52200 nM
The estimate for compound 4 lay 1.7-fold (0.24 log units) below the measured number, and the stated range covers the measured number.
By their numbers in this assay, from the lowest: compounds 2, 1, 3 and 4 (each within the scatter of the next).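

On a selenium whose other neighbour is aromatic carbon, hydrogen in place of methyl gives a 1.9-fold higher number from compound 2 to compound 4 (0.28 log units; within the scatter) in this assay and hydrogen in place of pentyl gives a 1.3-fold higher number from compound 1 to compound 4 (0.11 log units; within the scatter) on the same shared core. The earlier compounds shown here covered only pentyl and methyl on this selenium, and the series now shows that taking away the last carbon also leaves the number within the scatter, so hydrogen, methyl and pentyl at this position cannot be set apart in this read-out. Nothing measured besides growth inhibition bears on why these three substituents fall so close together.

Open, on these data alone, is whether any substituent on this selenium can move the number beyond the scatter, which a phenyl group, an aminoethyl chain or a chain ending in a carboxylic acid would test. Also open, as far as these compounds go, is how sulfur in place of the selenium would compare, and whether the core of compound 3 would respond to hydrogen, methyl and pentyl on the selenium as the core of compound 2 does.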